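The compounds below may be only part of what the source reports. "The series", "measured", "known", "first", "only" and "open" are said of these compounds alone.

The compounds here share one core and differ only in the group on an amine nitrogen in a ring. Compound 2, `CCCCN1CCc2nc(C#Cc3ccccc3)sc2C1`, carries a butyl group there. In an assay on HEK293 cells for negative allosteric modulation of metabotropic glutamate receptor 5 (Homo sapiens), read by FLIPR, with a stated time of 1 h (a higher number here means a weaker inhibitor, a lower number a stronger inhibitor), compound 2 gives > 10000 nM, which is a limit of the assay rather than a number. Compound 2 therefore stands at the limit of > 10000 nM in this assay, at which 2 of the 3 values shown sit, so no measured point is known for it. Compound 1, `CN1CCc2nc(C#Cc3cccc(F)c3)sc2C1`, carries a methyl group on that nitrogen and gives > 10000 nM in this assay, also a limit. Compound 3, `Fc1cccc(C#Cc2nc3c(s2)CN(C2CCOC2)CC3)c1`, carries an oxolan-3-yl group and gives 400 nM in this assay.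

Within the data shown here, the one measured step, an at least 25-fold lower number from compound 1 to compound 3 (1.39 log units; beyond the scatter), shows that exchanging the methyl for the ring-bearing oxolan-3-yl on that nitrogen brings a large fall in the number. Compound 4, `O=C(C1CCC1)N1CCc2nc(C#Cc3ccccc3)sc2C1`, is compound 2 with cyclobutylcarbonyl in place of butyl on an amine nitrogen in a ring. Among the measured compounds shown here, this too exchanges a plain chain for a ring-bearing group on the same nitrogen, so the measured step bears on it, though only loosely: the entering group carries a carbonyl, which no measured compound has, and the leaving group is butyl rather than methyl. A fall is expected, but a smaller and less certain one. For compound 4 the expected value in this assay is 2500 nM, ranging from 400 nM to 10000 nM. This amounts to an expected step of an at least 4.0-fold lower number from compound 2 to compound 4 (0.60 log units; beyond the scatter).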

Compound 4, half-maximal inhibitory concentration: 370 nM
The estimate for compound 4 lay 6.8-fold (0.83 log units) above the measured number; measured number outside the range, below it.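

In this assay, the change on this amine nitrogen in a ring gives an at least 27-fold lower number from compound 2 to compound 4 (1.43 log units; beyond the scatter), so the nitrogen responds strongly on the core of compound 2 as well as on the fluorine-bearing core of compound 1. Compound 2 itself stands at a limit of the assay rather than at a number, which leaves the true size of the step unknown: the limit of > 10000 nM in this assay, at which 2 of the 4 values shown sit. The entering group also differs in kind from oxolan-3-yl, bringing a carbonyl and a four-membered ring of carbon only, and among the compounds shown, the plain methyl and butyl groups sit at limits while both ring-bearing groups give measured values.

The ring and the carbonyl enter together in this step, so the compounds shown cannot tell which of them matters: acetyl on the same nitrogen would have the carbonyl without the ring, and cyclobutyl would have the ring without the carbonyl. Also open, on these data alone, is how far the ring on the carbonyl can change, for instance to a cyclohexyl or a phenyl ring.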